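This account rests on a few compounds, and the source may have more. Where it says the series, first, only, none or still open, it means among the compounds named here.

Three compounds of the series carry numbers in a functional assay (Cavia porcellus) with sulfonylurea receptors; K-ATP channels (Homo sapiens) as the target; on this read-out higher numbers stand for weaker inhibition and lower numbers for stronger inhibition. Compound 1 `COc1cc(NC(=O)C(C)(O)C(F)(F)F)ccc1S(=O)(=O)c1ccccc1` gives 5900 nM. Compound 2 `Cc1ccc(S(=O)(=O)c2ccc(NC(=O)C(C)(O)C(F)(F)F)cc2)cc1` reaches only a limit in this assay, > 30000 nM, and this is a limit rather than a number (the limit of > 30000 nM in this assay, at which 1 of the 3 values shown sits). Compound 3 `CC(O)(C(=O)Nc1ccc(C(=O)c2ccccc2)c(F)c1)C(F)(F)F` gives 2700 nM in this assay, the lower of the two numbers, with compound 1 as the nearest and a gap beyond the scatter. Compound 4 `CC(O)(C(=O)Nc1ccc(C(=O)c2ccccc2)c(O)c1)C(F)(F)F` has not been measured. It differs from compound 3 by hydroxy in place of fluoro on an aromatic carbon. Among the compounds with values here, no measured pair of the series shows this change. The step from compound 3 to compound 4 is expected to be small, about a 1.1-fold higher number from compound 3 to compound 4 (0.05 log units; within the scatter), in no direction beyond the scatter. For compound 4 in this assay the estimate is 3000 nM, within 1000 nM to 10000 nM.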

Compound 4, half-maximal inhibitory concentration: 4200 nM
Compound 4: middle estimate off by 1.4-fold (0.15 log units), on the low side; the range from low to high includes it.
By their numbers in this assay, from the lowest: compounds 3, 4 and 1 (each within the scatter of the next, the first and the last beyond it). At a limit, above all of these: compound 2.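

In this assay, within the data shown here, the first pair for hydroxy in place of fluoro on an aromatic carbon, ortho to a benzoyl group, gives a 1.6-fold higher number from compound 3 to compound 4 (0.19 log units; within the scatter). At this position, the exchange brings in a hydrogen-bond donor and a hydrogen-bond acceptor while the number stays within the scatter. Nothing measured here gives a cause for this step.

Going by these compounds, whether an amine or a carboxylic acid at this position would also stay within the scatter remains open. Also open, on these data alone, is whether the same exchange would read alike on the core of compound 1.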